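Replacing the bicyclic amine of compound 3 with 4-methylpiperidine

This account rests on a few compounds, and the source may have more. Where it says the series, first, only, none or still open, it means among the compounds named here.

Compound 1 `COc1cc2c(Oc3ccc(NC(=O)NN4C(=O)CSC4c4c(F)cccc4F)cc3Cl)ccnc2cc1OCCCN1CCCC1` gives 880 nM in a functional assay on A549 cells (Homo sapiens) for antiproliferative activity, read by MTT assay, with a stated time of 72 h; a higher number here means a weaker inhibitor, a lower number a stronger inhibitor. Compound 2 `COc1cc2c(Oc3c(F)cc(NC(=O)NN4C(=O)CCSC4c4c(F)cccc4F)cc3F)ccnc2cc1OCCCN1CCCC1` gives 400 nM in this assay. For compound 3 `COc1cc2c(Oc3c(F)cc(NC(=O)NN4C(=O)CCSC4c4c(F)cccc4F)cc3F)ccnc2cc1OCCCN1CCc2sccc2C1` this assay reports only a limit, > 20000 nM, and no number. Going by the values given here, the one step between measured neighbours, an at least 50-fold higher number from compound 2 to compound 3 (1.69 log units; beyond the scatter), is large, and its end point is set by the limit of > 20000 nM in this assay, at which 1 of the 3 values shown sits, so its true size is not known beyond that.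

Compound 4 `COc1cc2c(Oc3c(F)cc(NC(=O)NN4C(=O)CCSC4c4c(F)cccc4F)cc3F)ccnc2cc1OCCCN1CCC(C)CC1` differs from compound 3 by a group of 7 heavy atoms (6 carbon, 1 nitrogen; one six-membered non-aromatic ring with 1 hetero atom) in place of a group of 9 heavy atoms (7 carbon, 1 nitrogen, 1 sulfur; one five-membered aromatic ring with 1 hetero atom, one six-membered non-aromatic ring with 1 hetero atom), on a saturated chain carbon, three bonds along the chain from an oxygen on an aromatic ring. The group that enters is a six-membered saturated amine, closer in size to the five-membered amine of compound 2 than to the bicyclic group of compound 3, so the step of an at least 50-fold higher number from compound 2 to compound 3 (1.69 log units; beyond the scatter) is the relevant guide, taken in reverse. A large move to a lower number is therefore expected in this assay, with the size uncertain because compound 3 stands only at a limit.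

The step expected from compound 3 to compound 4 is an at least 22-fold lower number from compound 3 to compound 4 (1.34 log units; beyond the scatter). Compound 4 is estimated at 900 nM, with a likely range of 300 nM to 5000 nM, placed somewhat above compound 2 at 400 nM since the entering ring is larger than the pyrrolidine there.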

Compound 4, half-maximal inhibitory concentration: 1630 nM
Compound 4: the middle estimate sits 1.8-fold (0.26 log units) below what was measured, and the stated range covers the measured number.
By their numbers in this assay, from the lowest: compound 2; then compounds 1 and 4 (each within the scatter of the next). At a limit, above all of these: compound 3.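

At this saturated chain carbon, three bonds along the chain from an oxygen on an aromatic ring, a larger amine does not by itself abolish the read-out in this assay: 4-methylpiperidin-1-yl in place of the bicyclic amine gives an at least 12-fold lower number from compound 3 to compound 4 (1.08 log units; beyond the scatter). Going by these compounds alone, the amine is still not interchangeable, since 4-methylpiperidin-1-yl in place of pyrrolidin-1-yl gives a 4.1-fold higher number from compound 2 to compound 4 (0.61 log units; beyond the scatter), which is the only step at this position with a measured number at both ends. The full size of the step from the bicyclic amine stays unknown because that step ends at a limit: the limit of > 20000 nM in this assay, at which 1 of the 4 values shown sits.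

The compounds shown leave open whether the rise in number from pyrrolidin-1-yl to 4-methylpiperidin-1-yl goes with the larger ring or with the methyl group, a question that piperidin-1-yl would separate. Also open, from the compounds shown here alone, is how an amine carrying a further hetero atom, such as morpholin-4-yl or 4-methylpiperazin-1-yl, would stand on the same chain, and whether the same order would hold on the core of compound 1.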